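The source may report more compounds than this note shows. Statements on the series, on what has been measured and on what is new or still open speak of the compounds shown alone.

Measured so far in an ADME assay on MDCK cells (Canis lupus familiaris) for permeability; on this read-out higher numbers stand for higher permeability and lower numbers for lower permeability:
- Compound 1 `COc1cc(C(F)(F)F)ccc1-c1cccc2cc(S(=O)(=O)Nc3ncns3)ccc12`: 17 10^-6 cm/s
- Compound 2 `COc1cc(C(F)(F)F)ccc1-c1cccc2cc(S(=O)(=O)Nc3ccncn3)ccc12`: 27 10^-6 cm/s

With only these two numbers available, compound 2 at 27 10^-6 cm/s stands level with compound 1 at 17 10^-6 cm/s, because the gap is a 1.6-fold higher number from compound 1 to compound 2 (0.20 log units; within the scatter). In other words, repeat measurements could account for the whole difference.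

The next compound to be tested is compound 3 `COc1cc(C(F)(F)F)ccc1-c1cccc2cc(S(=O)(=O)Nc3ccccn3)ccc12`. It keeps the shared core of compound 2 and changes a single group: pyridin-2-yl in place of pyrimidin-4-yl on a sulfonamide nitrogen. In words, pyridin-2-yl takes the place of pyrimidin-4-yl on a sulfonamide nitrogen.

Going by the values given here, only one measured step bears on this change. It was made on the same sulfonamide nitrogen, where pyrimidin-4-yl replaced 1,2,4-thiadiazol-5-yl, and it gave a 1.6-fold higher number from compound 1 to compound 2 (0.20 log units; within the scatter). A single small step is thin evidence, but it gives no reason to expect a large shift in this assay, so no step beyond the scatter is expected, in either direction. The expected change is a 1.1-fold lower number from compound 2 to compound 3 (0.03 log units; within the scatter).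

For compound 3 the estimated value is 25 10^-6 cm/s, with an expected range from 12 10^-6 cm/s to 45 10^-6 cm/s.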

Compound 3, apparent permeability: 9.5 10^-6 cm/s
Beside the measured number, compound 3's estimate is 2.6-fold (0.42 log units) above it, outside the stated range (below it).
By their numbers in this assay, from the lowest: compounds 3, 1 and 2 (each within the scatter of the next, the first and the last beyond it).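

Going by these compounds alone, this result shows that the ring on the sulfonamide nitrogen can matter in this assay: the change to pyridin-2-yl gives a 2.8-fold lower number from compound 2 to compound 3 (0.45 log units; beyond the scatter), the first step in this short series that lies beyond the scatter. The change itself is small, since the ring keeps its size and its count of heavy atoms, and the pyrimidin-4-yl ring of 4 carbon and 2 nitrogen atoms becomes a pyridin-2-yl ring of 5 carbon atoms and 1 nitrogen atom. The other new comparison, with 1,2,4-thiadiazol-5-yl on the same nitrogen, gives a 1.8-fold lower number from compound 1 to compound 3 (0.25 log units; within the scatter) and stays within the scatter, so compound 3 stands clearly apart only from compound 2, and the three groups do not yet form a reliable ranking.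

Nothing measured here explains why this exchange of one ring atom goes with such a step. Still open, from the compounds shown here alone, is what a plain phenyl ring, with no ring nitrogen at all, would give on this sulfonamide nitrogen, and whether the step from pyrimidin-4-yl to pyridin-2-yl would be repeated on a different core.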